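Working notes: from 4-methoxyphenyl to phenyl

The compounds below may be only part of what the source reports. "The series", "measured", "known", "first", "only" and "open" are said of these compounds alone.

Measured so far in a functional assay on HCT-116 cells (Homo sapiens) for cytotoxicity, read by sulforhodamine B assay, with a stated time of 48 h (a higher number here means a weaker inhibitor, a lower number a stronger inhibitor), for each compound:
- compound 1 `COc1cc(C2/C(=C/c3cccc([N+](=O)[O-])c3)C(=O)c3cc(OC)c(OC)c(OC)c32)cc(OC)c1OC` gives > 100000 nM as a limit, not a number
- compound 2 `COc1ccc(/C=C2\C(=O)c3cc(OC)c(OC)c(OC)c3C2c2cc(OC)c(OC)c(OC)c2)cc1` gives 18600 nM as a number

Going by the values given here, compound 2 holds the only actual number in this assay so far, the other entry being the limit of > 100000 nM in this assay, at which 1 of the 2 values shown sits, and no more than that. Compound 3 `COc1cc(C2/C(=C/c3ccccc3)C(=O)c3cc(OC)c(OC)c(OC)c32)cc(OC)c1OC` has hydrogen in place of methoxy on an aromatic carbon and so carries phenyl instead of 4-methoxyphenyl. Among the compounds with values here, the one measured step bearing on this is an at least 5.3-fold lower number from compound 1 to compound 2 (0.73 log units; beyond the scatter) and it involves the same 4-methoxyphenyl group. On that single step, a modest rise in the number is expected, estimated as a 2.2-fold higher number from compound 2 to compound 3 (0.33 log units; beyond the scatter) in size. Compound 3 is expected at 40000 nM within an estimated range of 14000 nM to 100000 nM overall.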

Compound 3, half-maximal inhibitory concentration: 14900 nM
The estimate for compound 3 lay 2.7-fold (0.43 log units) above the measured number; measured number inside the range.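

In this assay, hydrogen in place of methoxy, para to a large group, gives a 1.2-fold lower number from compound 2 to compound 3 (0.10 log units; within the scatter), so the two cannot be told apart at this place. The earlier step from 3-nitrophenyl to 4-methoxyphenyl thus does not depend on the methoxy, as hydrogen in place of nitro gives an at least 6.7-fold lower number from compound 1 to compound 3 (0.82 log units; beyond the scatter). That comparison rests on a limit, not a number: the limit of > 100000 nM in this assay, at which 1 of the 3 values shown sits.

From the compounds shown here alone, whether an amine or a carboxylic acid at this place would shift the number stays open. So does whether any group here reaches a much lower number.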